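A few compounds are considered here, and "the series" means these few. Any claim that something is new, unique, unknown or untested is made for them only; others in the source may bear on it.

Of the compounds shown here, three built on one shared core have been tested in a functional assay on NCI-H1975 cells (Homo sapiens) for antiproliferative activity, with a stated time of 72 h; on this read-out higher numbers stand for weaker inhibition of growth and lower numbers for stronger inhibition of growth. There compound 1 `COc1cc(CN(C)C(=O)c2cc(Cl)c(O)cc2O)c(Cl)c(OC)c1OC` gives 33800 nM, compound 2 `COc1ccc(CN(C)C(=O)c2cc(Cl)c(O)cc2O)cc1OC` gives 33400 nM and compound 3 `Cc1cccc(CN(C)C(=O)c2cc(Cl)c(O)cc2O)c1` gives 49300 nM. Compound 2 therefore stands level with the other two, since its gaps to compound 1 and to compound 3 both lie within the usual scatter of such measurements.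

Compound 4 `COc1cc(CN(C)C(=O)c2cc(Cl)c(O)cc2O)cc(OC)c1OC` is compound 2 with a single alteration, methoxy in place of hydrogen on an aromatic carbon: a methoxy in place of hydrogen on an aromatic carbon, ortho to a methoxy group already there. Among the compounds with values here, no measured pair isolates this change, so the evidence is indirect. Compound 1 differs from compound 2 in more than one place, yet the value of compound 2 at 33400 nM and that of compound 1 at 33800 nM lie within the scatter. In this assay no step beyond the scatter is therefore expected, in either direction. The expected step is a 1.0-fold higher number from compound 2 to compound 4 (0.02 log units; within the scatter). For compound 4 the estimated value is 35000 nM, with an expected range from 18000 nM to 65000 nM.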

Compound 4, concentration for 50% growth inhibition: 73100 nM
Compound 4: the middle estimate sits 2.1-fold (0.32 log units) below what was measured, outside the stated range (above it).
By their numbers in this assay, from the lowest: compounds 2, 1, 3 and 4 (each within the scatter of the next, the first and the last beyond it).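

In this assay, within the data shown here, the first step beyond the scatter appears: placing a methoxy on the aromatic carbon ortho to a methoxy group already there gives a 2.2-fold higher number from compound 2 to compound 4 (0.34 log units; beyond the scatter) and so weakens growth inhibition modestly. The chloro on this ring also matters once the three methoxy groups are present, since replacing it with hydrogen gives a 2.2-fold higher number from compound 1 to compound 4 (0.34 log units; beyond the scatter) in the same direction. Nothing measured here accounts for either step.

Going by these compounds, it remains open whether the loss follows from methoxy itself or would also appear with a smaller or different group on that carbon, such as fluoro, hydroxy or an amine. A longer chain, such as ethoxy, could show whether the size of the group there affects the read-out.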